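Swapping the Aryl Group on Compound 2

The source may hold more compounds than are shown below. What is called first, only, known or untested is meant among the compounds shown, and "the series" means these compounds.

In a functional assay on DU-145 cells (Homo sapiens) for cytotoxicity, read by sulforhodamine B assay, with a stated time of 48 h (on this read-out lower numbers stand for stronger inhibition and higher numbers for weaker inhibition), compound 2 `C[C@H]1CC[C@@H]2[C@@H](OC(=O)[C@]23CC(c2ccccc2[N+](=O)[O-])=NO3)[C@]2(C)C(=O)C=C[C@@]12O` gives 34000 nM and stands level with its two relatives, all within the usual scatter. Compound 1 `C[C@H]1CC[C@@H]2[C@@H](OC(=O)[C@]23CC(c2ccccc2Br)=NO3)[C@]2(C)C(=O)C=C[C@@]12O` gives 18000 nM on the same core, and compound 3 `C[C@H]1CC[C@@H]2[C@@H](OC(=O)[C@]23CC(c2ccccc2Cl)=NO3)[C@]2(C)C(=O)C=C[C@@]12O` gives 19000 nM there too. Compound 4 `Cc1cccc(C2=NO[C@]3(C2)C(=O)O[C@@H]2[C@H]3CC[C@H](C)[C@]3(O)C=CC(=O)[C@@]23C)c1` has 3-methylphenyl in place of 2-nitrophenyl on a carbon with a double bond to nitrogen. Three measured swaps on the aromatic ring bear on this: nitro for bromo (a 1.9-fold higher number from compound 1 to compound 2 (0.28 log units; within the scatter)), chloro for bromo (a 1.1-fold higher number from compound 1 to compound 3 (0.02 log units; within the scatter)) and chloro for nitro (a 1.8-fold lower number from compound 2 to compound 3 (0.25 log units; within the scatter)). Among the compounds with values here, all stayed small, though no measured compound carries a methyl group. No step beyond the scatter is therefore expected in this assay (a 1.4-fold lower number from compound 2 to compound 4 (0.13 log units; within the scatter) as estimated). Compound 4 is estimated at 25000 nM (expected range 11000 nM to 55000 nM).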

Compound 4, half-maximal inhibitory concentration: 28000 nM
Estimate against measurement, compound 4: 1.1-fold (0.05 log units) below; low and high end bracket the measured number.
By their numbers in this assay, from the lowest: compounds 1, 3, 4 and 2 (each within the scatter of the next).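

In this assay, within the data shown here, 3-methylphenyl brings in a methyl group that no earlier compound carried and has 0 hydrogen-bond acceptors where 2-nitrophenyl has 2, yet the step stays within the scatter (a 1.2-fold lower number from compound 2 to compound 4 (0.08 log units; within the scatter)). The same holds against the two halogen-bearing compounds (a 1.5-fold higher number from compound 3 to compound 4 (0.17 log units; within the scatter); a 1.6-fold higher number from compound 1 to compound 4 (0.19 log units; within the scatter)), so all four aryl groups on the shared core read alike here. No evidence is available on why these numbers sit together. Still open, on these data alone, is whether an amine or a carboxylic acid on the aromatic ring, or a longer chain in place of that ring, would move the number beyond the scatter.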